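Hydroxy for Methyl on the Amide Side Chain

The source may report more compounds than this note shows. Statements on the series, on what has been measured and on what is new or still open speak of the compounds shown alone.

Compound 1, `CCCCCCCCN(C)C(=O)Cn1cc(Cc2cnc(=O)n(CC(=O)O)c2)c(=O)nc1SCc1ccc(F)cc1`: 27%
Compound 2, `CCCCCCCCN(C)C(=O)Cn1cc(Cc2cnc(=O)n(CC(=O)NC)c2)c(=O)nc1SCc1ccc(F)cc1`: 42%
Compound 3, `CCCCCCCCN(C)C(=O)Cn1cc(Cc2cnc(=O)n(CC(=O)NCCC)c2)c(=O)nc1SCc1ccc(F)cc1`: 16%

Of the compounds shown here, three sharing one core have been measured in a functional assay on a cell-free system (plasma, Oryctolagus cuniculus) for inhibition of platelet-activating factor acetylhydrolase (Homo sapiens), tested at 100 nM; a higher number here means more inhibition at the concentration tested (going by the name of the read-out), a lower number less inhibition. Compound 3 stands lowest of the three: compound 1 lies nearest, with a step of a number 11 percentage points lower from compound 1 to compound 3 (beyond the scatter), and compound 2 lies furthest, with a step of a number 26 percentage points lower from compound 2 to compound 3 (beyond the scatter). Both steps are beyond the scatter.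

Compound 4, `CCCCCCCCN(C)C(=O)Cn1cc(Cc2cnc(=O)n(CC(=O)NCCO)c2)c(=O)nc1SCc1ccc(F)cc1`, has not yet been measured. It differs from compound 3 by hydroxy in place of methyl on a saturated chain carbon, two bonds along the chain from an amide-type nitrogen.

Within the data shown here, no measured step swaps a methyl for a hydroxy, so none bears on this change directly. The closest guide is the step of a number 26 percentage points lower from compound 2 to compound 3 (beyond the scatter), which shows that lengthening the chain on the amide-type nitrogen by an ethyl lowered inhibition by a modest amount. Compound 4 keeps the chain length of compound 3 but ends it in a hydroxy instead of a methyl. With no measured hydroxy-bearing chain to compare, the expectation is for a small rise at most, of a size near the scatter.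

The expected step is a number 8 percentage points higher from compound 3 to compound 4 (within the scatter). Compound 4 is therefore estimated at 24%, within a range from 10% to 40%.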

Compound 4, a percentage reported as inhibition, at one concentration (the size of the read-out at that concentration, not a potency): 40%
Compound 4: the middle estimate sits 16 percentage points below what was measured; the range from low to high includes it.
By their numbers in this assay, from the lowest: compound 3; then compound 1; then compounds 4 and 2 (each within the scatter of the next).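

In this assay, hydroxy in place of methyl on a saturated chain carbon, two bonds along the chain from an amide-type nitrogen, gives a number 24 percentage points higher from compound 3 to compound 4 (beyond the scatter), so a swap of a single heavy atom at this place is enough to change the read-out. The (2-hydroxyethyl)amino group in place of the hydroxy on the carbonyl carbon gives a number 13 percentage points higher from compound 1 to compound 4 (beyond the scatter), while hydroxymethyl in place of hydrogen on the saturated chain carbon bound to the amide-type nitrogen gives a number 2 percentage points lower from compound 2 to compound 4 (within the scatter), so the hydroxy-bearing chain and the short methylamino group cannot be told apart here. No supporting information accompanies these numbers, so the reason for the rise remains unknown.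

Going by these compounds, whether the hydroxy itself matters or any similar end group would do stays open: a methoxy, an amine or a carboxylic acid at the same place would test this. A longer chain ending in hydroxy would show how far the chain can grow before the number falls, and each reading here comes from a single concentration, so it gives no potency.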